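Cytotoxicity Limits Along an Amide Series

A few compounds are considered here, and "the series" means these few. Any claim that something is new, unique, unknown or untested is made for them only; others in the source may bear on it.

In a toxicity assay on HepG2 cells (Homo sapiens) for inhibition, read by CellTiter-Glo, with a stated time of 48 h (a lower number here means a stronger inhibitor, a higher number a weaker inhibitor), the three measured compounds gave the following.
Compound 1, `COc1ccc2nc(C(F)(F)F)cc(OCC(=O)Nc3cc(C)cc(C)c3)c2c1`: > 100000 nM
Compound 2, `COc1ccc2nc(C)cc(OCC(=O)Nc3cc(F)cc(F)c3)c2c1`: > 100000 nM
Compound 3, `COc1ccc2nc(C)cc(OCC(=O)Nc3ccc(S(=O)(=O)Nc4cc(C)on4)cc3)c2c1`: > 100000 nM

Each of these is a limit of the assay rather than a number: the limit of > 100000 nM in this assay, at which 3 of the 3 values shown sit. Compound 2 therefore stands where every compound stands so far, at the limit, with no measured number to rank it against the others.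

Compound 4, `COc1ccc2nc(C)cc(OCC(=O)NNC(=O)c3ccncc3)c2c1`, differs from compound 2 in one place: ((pyridin-4-yl)carbonyl)amino in place of 3,5-difluorophenyl on an amide-type nitrogen.

For the measured compounds named here, no step between measured compounds is available to guide this change. The step of a number no higher from compound 2 to compound 4 (the limit leaves the size open) is expected to be none beyond the scatter. Compound 4 is estimated at 100000 nM, between 40000 nM and 300000 nM, and is expected most likely to be reported again only as a limit in this assay.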

Compound 4, half-maximal inhibitory concentration: > 100000 nM
Compound 4 was reported as a limit; the forecaster's own chance of this, stated with the estimate: 85%; the middle value lies on the limit itself.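

Compound 2 and compound 4 are both reported only as limits of the assay, so no step can be read between them: the limit of > 100000 nM in this assay, at which 4 of the 4 values shown sit.

In this assay the compounds shown leave open how the four rank against one another and which change would give a readable number.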